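This account rests on a few compounds, and the source may have more. Where it says the series, first, only, none or still open, it means among the compounds named here.

Compound 1 `O=c1c(C(=S)Nc2ccccc2)coc2cc(Cl)ccc12` and compound 2 `O=c1c(C2N=C(c3ccccc3)SS2)coc2ccc(Cl)cc12` both carry a chloro substituent on a fused core, but they differ elsewhere; the difference between the two cores is not broken down here. In a functional assay on HEp-2 cells (Homo sapiens) for inhibition, read by sulforhodamine B assay, with a stated time of 48 h, tested at 100 uM (on this read-out lower numbers stand for less inhibition of growth and higher numbers for more inhibition of growth at the one concentration tested), compound 1 gives 41%, and compound 2 gives 69%. Compound 3 `O=c1c(C2N=C(c3ccccc3)SS2)coc2ccccc12`, with hydrogen in place of chloro on an aromatic carbon, gives 48% in this assay; the step of a number 21 percentage points lower from compound 2 to compound 3 (beyond the scatter) corresponds to the change (hydrogen in place of chloro on an aromatic carbon). Compound 4 `O=c1c(C(=S)Nc2ccccc2)coc2ccccc12` stands to compound 1 as compound 3 stands to compound 2, the change being (hydrogen in place of chloro on an aromatic carbon), the same change at the same kind of place, which occurs twice among these compounds. Among the measured compounds shown here, because the one measured step of a number 21 percentage points lower from compound 2 to compound 3 (beyond the scatter) was modest, compound 4 is expected to show a step of about a number 19 percentage points lower from compound 1 to compound 4 (beyond the scatter) in this assay. Compound 4 is thus estimated at 22%, likely between 5% and 40%.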

Compound 4, percent growth inhibition at one concentration: 32%
The estimate for compound 4 lay 10 percentage points below the measured number; the range from low to high includes it.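

In this assay, hydrogen in place of chloro on an aromatic carbon gives a number 9 percentage points lower from compound 1 to compound 4 (within the scatter). Set beside the earlier step, the new one does not separate the two cores: the same change on two cores in this assay, a number 21 percentage points lower (beyond the scatter) from compound 2 to compound 3 and a number 9 percentage points lower (within the scatter) from compound 1 to compound 4, 12 percentage points apart, within the scatter of two such steps This shows no measurable dependence of the change on the core, but it does not show that the change carries over with a reliable effect, since only the step on the core of compound 2 lies beyond the scatter and two cores at one concentration support no general rule.

The compounds shown leave open how other groups would behave in place of chloro, such as a methoxy group, an amine or a carboxylic acid.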